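The source may hold more compounds than are shown below. What is called first, only, known or untested is meant among the compounds shown, and "the series" means these compounds.

Among the compounds with values here, compound 2, with the structure `N#CCC(=O)N/N=C1\C(=O)Nc2ccc(S(=O)(=O)N3CCOCC3)cc21`, stands lowest of the two numbers so far in a functional assay on HepG2 cells (Homo sapiens) for cytotoxicity, read by sulforhodamine B assay, with a stated time of 24 h (on this read-out lower numbers stand for stronger inhibition and higher numbers for weaker inhibition), where compound 2 gives 7530 nM. Within the data shown here, its only measured neighbour is compound 1, `O=C1Nc2ccc(S(=O)(=O)N3CCOCC3)cc2/C1=N/NC(=O)c1ccccc1`, which in this assay gives 18100 nM; the step of a 2.4-fold lower number from compound 1 to compound 2 (0.38 log units; beyond the scatter) came from putting cyanomethyl in place of phenyl on a carbonyl carbon.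

Compound 3, `O=C1Nc2ccc(S(=O)(=O)N3CCOCC3)cc2/C1=N/c1cccc(C(F)(F)F)c1`, is a different kind of change. Here the whole ((cyanomethyl)carbonyl)amino group that hangs on the double-bonded nitrogen is gone, and a 3-(trifluoromethyl)phenyl ring sits there instead: 3-(trifluoromethyl)phenyl in place of ((cyanomethyl)carbonyl)amino on a double-bonded nitrogen. The shared core with its morpholine-bearing sulfonyl group stays untouched.

Among the measured compounds shown here, no measured step touches the double-bonded nitrogen itself, so the one step seen, a 2.4-fold lower number from compound 1 to compound 2 (0.38 log units; beyond the scatter), bears on it only loosely: it shows that swapping what hangs off this side of the core moves the number modestly, in either direction. With nothing closer to go on, the expectation for compound 3 in this assay is a step of about a 1.3-fold higher number from compound 2 to compound 3 (0.12 log units; within the scatter), within the scatter. Compound 3 is therefore estimated at 10000 nM, most likely between 3000 nM and 40000 nM.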

Compound 3, half-maximal inhibitory concentration: 14300 nM
For compound 3 the middle estimate is 1.4-fold (0.16 log units) below the measured one, and the stated range covers the measured number.
By their numbers in this assay, from the lowest: compounds 2, 3 and 1 (each within the scatter of the next, the first and the last beyond it).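

In this assay, the double-bonded nitrogen takes two very different kinds of group with no change that stands clear of the scatter: a 1.9-fold higher number from compound 2 to compound 3 (0.28 log units; within the scatter) and a 1.3-fold lower number from compound 1 to compound 3 (0.10 log units; within the scatter) are both within it. The earlier step only exchanged the group on a carbonyl carbon, whereas 3-(trifluoromethyl)phenyl replaces the whole of ((cyanomethyl)carbonyl)amino or benzamido on this nitrogen, and the hydrogen-bond donor and acceptors counted in ((cyanomethyl)carbonyl)amino are absent from the group that enters, yet compound 2 and compound 3 cannot be told apart in this assay. No measurement shown here accounts for this result.

The compounds shown leave open whether 3-(trifluoromethyl)phenyl itself matters, since a plain phenyl ring on the same nitrogen would be needed to separate the ring from the trifluoromethyl group. They also leave open how the number would respond if an amine or a carboxylic acid stood on that ring in place of trifluoromethyl, and whether the closeness of compound 2 and compound 3 would hold with the morpholine on the sulfonyl group exchanged for another ring.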